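Chain extension notes: compound 2 to compound 3

The source may report more compounds than this note shows. Statements on the series, on what has been measured and on what is new or still open speak of the compounds shown alone.

Measured so far in a functional assay on J774.1 cells (Mus musculus) for inhibition, read by Griess assay; on this read-out lower numbers stand for stronger inhibition and higher numbers for weaker inhibition:
Compound 1 `CCCCCCCCS(=O)(=O)NCCCNCCCNCCCCNCCCN` gives 6470 nM
Compound 2 `CCCCCCCCCCS(=O)(=O)NCCCNCCCNCCCCNCCCN` gives 1090 nM

Compound 2 stands lowest of the two measured (1090 nM). Compound 3 `CCCCCCCCCCCCS(=O)(=O)NCCCNCCCNCCCCNCCCN` differs from it by one change (ethyl in place of hydrogen on a saturated chain carbon, ten or more bonds along the chain from a sulfonyl sulfur). Among the compounds with values here, one measured step bears on this, the same ethyl in place of hydrogen at eight bonds along the chain from a sulfonyl sulfur (a 5.9-fold lower number from compound 1 to compound 2 (0.77 log units; beyond the scatter)). A single step cannot show whether the trend continues, so a further fall in this assay is expected, of similar or smaller size. The estimate means an expected step of this kind (a 2.7-fold lower number from compound 2 to compound 3 (0.44 log units; beyond the scatter)). Estimated for compound 3: 400 nM as the middle, with 130 nM to 1200 nM as the expected range.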

Compound 3, half-maximal inhibitory concentration: 390 nM
Beside the measured number, compound 3's estimate is 1.0-fold (0.01 log units) above it; low and high end bracket the measured number.
By their numbers in this assay, from the lowest: compound 3; then compound 2; then compound 1.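

In this assay the number keeps falling as the chain grows: ethyl in place of hydrogen on a saturated chain carbon gives a 2.8-fold lower number from compound 2 to compound 3 (0.45 log units; beyond the scatter) and so extends the fall seen at eight bonds. Butyl in place of hydrogen at eight bonds gives a 17-fold lower number from compound 1 to compound 3 (1.22 log units; beyond the scatter) on the shared core. Nothing available accounts for this trend.

Going by these compounds, whether a longer chain lowers the number further or the fall stops remains open. So does the effect of an amine or a carboxylic acid at the chain end.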